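Dichloroacetanilides: meta substituent swap, nitro to methoxy

The source may hold more compounds than are shown below. What is called first, only, known or untested is meant among the compounds shown, and "the series" means these compounds.

Measured compounds:
- compound 1 `Cc1cccc(NC(=O)C(Cl)Cl)c1`: "not determined" (no result reported) in a functional assay on KB cells (Homo sapiens) for antiproliferative activity, read by MTT assay, with a stated time of 72 h; a lower number here means a stronger inhibitor, a higher number a weaker inhibitor
- compound 2 `O=C(Nc1cccc(I)c1)C(Cl)Cl`: 5250 nM
- compound 3 `O=C(Nc1cccc([N+](=O)[O-])c1)C(Cl)Cl`: 44700 nM

For the measured compounds named here, compound 3 stands highest of the two numbers in this assay; its nearest neighbour is compound 2, and the single step with one change, an 8.5-fold higher number from compound 2 to compound 3 (0.93 log units; beyond the scatter), is the only measured step that bears on compound 4 `COc1cccc(NC(=O)C(Cl)Cl)c1`. The change to compound 4 is methoxy in place of nitro on an aromatic carbon. Going by the values given here, since nitro arriving at that position raised the number modestly, removing it and placing methoxy there is expected to lower the number again, though a methoxy in place of iodo has no measured precedent, so the size is uncertain. The estimated step is a 3.7-fold lower number from compound 3 to compound 4 (0.57 log units; beyond the scatter) for compound 4. Compound 4 is therefore expected to give about 12000 nM, within 3500 nM to 40000 nM.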

Compound 4, half-maximal inhibitory concentration: 57700 nM
For compound 4 the middle estimate is 4.8-fold (0.68 log units) below the measured one, outside the stated range (above it).
By their numbers in this assay, from the lowest: compound 2; then compounds 3 and 4 (each within the scatter of the next).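

In this assay, the swap of nitro for methoxy on this aromatic carbon gives a 1.3-fold higher number from compound 3 to compound 4 (0.11 log units; within the scatter), so these two groups are not separated here. Iodo alone stands apart, with an 11-fold higher number from compound 2 to compound 4 (1.04 log units; beyond the scatter) matching the earlier gap to nitro. No available evidence accounts for this difference between groups.

Compound 1 stands at "not determined" (no result reported), so steps involving it cannot be read. As far as these compounds go, whether the lower number of compound 2 is particular to iodo or extends to bromo, an amine or a carboxylic acid at this position remains open.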